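A few compounds are considered here, and "the series" means these few. Any claim that something is new, unique, unknown or untested is made for them only; others in the source may bear on it.

In an ADME assay on the whole organism (Rattus norvegicus, strain Sprague-Dawley) for pharmacokinetics, read by LC-MS (on this read-out lower numbers stand for lower oral bioavailability and higher numbers for higher oral bioavailability), compound 2 `N#Cc1ccc(O[C@H]2CN(S(=O)(=O)c3ccc(Cl)cn3)C[C@@]2(O)CO)cc1F` gives 100%, level with compound 1 `N#Cc1ccc(O[C@H]2CN(S(=O)(=O)c3ccc(C(F)(F)F)cc3)C[C@@]2(O)CO)cc1F`, which gives 100%. Compound 3 `N#Cc1ccc(O[C@H]2CN(S(=O)(=O)c3ccc(Cl)cc3)C[C@@]2(O)CO)cc1F` has 4-chlorophenyl in place of 5-chloropyridin-2-yl on a sulfonyl sulfur. Going by the values given here, only one measured step bears on this swap, an exchange of groups at that same sulfur, and it showed no change at the digits printed from compound 1 to compound 2 (within the scatter). One step is thin evidence, but it gives no reason to expect a shift beyond the scatter in this assay, so the expected step is a number 8 percentage points lower from compound 2 to compound 3 (within the scatter). The estimate for compound 3 is 92%, with an expected range of 72% to 100%.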

Compound 3, oral bioavailability: 83%
Compound 3: the middle estimate sits 9 percentage points above what was measured; the measured number falls inside the stated range.
By their numbers in this assay, from the lowest: compound 3; then compounds 1 and 2 (each within the scatter of the next).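

The group on the sulfonyl sulfur can alter this assay after all: 4-chlorophenyl in place of 5-chloropyridin-2-yl gives a number 17 percentage points lower from compound 2 to compound 3 (beyond the scatter). Chloro in place of trifluoromethyl on an aromatic carbon gives a number 17 percentage points lower from compound 1 to compound 3 (beyond the scatter), so two separate single changes both reach beyond the scatter. Nothing available here offers a reason for either step.

Still open, going by these compounds, is how a methoxy group or an amine in place of that chloro would read out, and whether a chloro-free pyridine ring would hold the level of compound 2.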